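The source may hold more compounds than are shown below. What is called first, only, known or untested is meant among the compounds shown, and "the series" means these compounds.

Measured so far in an ADME assay on L6 cells (Rattus norvegicus) for cytotoxicity, with a stated time of 72 h; on this read-out higher numbers stand for weaker inhibition and lower numbers for stronger inhibition:
- compound 1 (`CN(C)C12CC(OC(=O)CN3CCCC3)C(C(c3ccccc3)C1)C(c1ccccc1)C2`) gives 32700 nM
- compound 2 (`CCN(CC)CC(=O)OC1CC2(N3CCCC3)CC(c3ccccc3)C1C(c1ccccc1)C2`) gives 49000 nM
- compound 3 (`CC(=O)OC1CC2(N3CCCCC3)CC(c3ccccc3)C1C(c1ccccc1)C2`) is recorded as "not determined" (no result reported) and has no number

Going by the values given here, only two numbers exist here, and they lie within the usual scatter of repeated measurements. Compound 1 therefore stands level with compound 2, and a repeat run might not separate them. Compound 3 adds nothing to this comparison.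

The next compound to be tested is compound 4 (`CN(C)C12CC(OC(=O)CN3CCCCC3)C(C(c3ccccc3)C1)C(c1ccccc1)C2`). It keeps the core of compound 1 and changes one group: piperidin-1-yl in place of pyrrolidin-1-yl on a saturated chain carbon bound to a carbonyl carbon. In words, piperidin-1-yl takes the place of pyrrolidin-1-yl on a saturated chain carbon bound to a carbonyl carbon.

Among the compounds with values here, no two measured compounds differ in one place only, so the data give no direct guide to the size of such a step. Within the data shown here, the only numbers to go on are compound 1 at 32700 nM and compound 2 at 49000 nM, which sit close together. On that thin basis, no change beyond the scatter is expected in this assay. The expected change is a 1.1-fold higher number from compound 1 to compound 4 (0.03 log units; within the scatter) and would lie within that scatter. The estimate for compound 4 is 35000 nM with an expected range from 15000 nM to 80000 nM for the measurement.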

Compound 4, half-maximal inhibitory concentration: 29300 nM
For compound 4 the middle estimate is 1.2-fold (0.08 log units) above the measured one; low and high end bracket the measured number.
By their numbers in this assay, from the lowest: compounds 4, 1 and 2 (each within the scatter of the next).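

Going by these compounds alone, this is the first pair in the set that differs in one place only, so the size of such a step can now be read directly. In this assay, piperidin-1-yl in place of pyrrolidin-1-yl on a saturated chain carbon bound to a carbonyl carbon gives a 1.1-fold lower number from compound 1 to compound 4 (0.05 log units; within the scatter) and so stays within the usual scatter of repeated measurements. For this pair, then, exchanging the five-membered non-aromatic ring for the six-membered one leaves no readable mark on this cytotoxicity measure, and nothing measured here speaks to what lies behind that outcome.

One pair cannot show whether this holds for other groups at the same place, such as morpholin-4-yl, which carries an oxygen atom in its ring, or a carboxylic acid, which would replace the ring amine altogether. It also leaves open whether the same exchange would stay as small on a core other than that of compound 1, so the result should be taken as a single step and not as a general rule.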